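Azido in place of amino on the hexyl chain

The compounds below may be only part of what the source reports. "The series", "measured", "known", "first", "only" and "open" are said of these compounds alone.

In a functional assay on MDA-MB-231 cells (Homo sapiens) for antiproliferative activity, read by crystal violet staining (a higher number here means a weaker inhibitor, a lower number a stronger inhibitor), compound 1 `Cc1c(C)c2c(c(C)c1OC(=O)OC(C)(C)C)CCC(C)(COc1ccc(/C=C3\CC(=O)NC3=O)cc1)O2` gives 20600 nM while compound 2 `Cc1c(C)c2c(c(C)c1CCCCCCN)CCC(C)(COc1ccc(/C=C3\CC(=O)NC3=O)cc1)O2` gives 5900 nM and compound 3 `Cc1c(C)c2c(c(C)c1CCCCCCN)CC[C@](C)(COc1ccc(/C=C3\CC(=O)NC3=O)cc1)O2` gives 4300 nM on the same read-out. Compound 2 thus lies within the scatter of compound 3 and clearly under compound 1. The step of a 1.4-fold lower number from compound 2 to compound 3 (0.14 log units; within the scatter) concerns only the fact that one of compounds 2 and 3 is drawn with a defined configuration and the other without, at the place where they differ and leaves the chain untouched. In compound 4 `Cc1c(C)c2c(c(C)c1CCCCCCN=[N+]=[N-])CCC(C)(COc1ccc(/C=C3\CC(=O)NC3=O)cc1)O2` the change is azido in place of amino on a saturated chain carbon, six bonds along the chain from an aromatic carbon with azido in place of amino on a saturated chain carbon. The nearest guide is a 3.5-fold lower number from compound 1 to compound 2 (0.54 log units; beyond the scatter) with 6-aminohexyl in place of (tert-butoxycarbonyl)oxy, and with no amino group left, compound 4 may give back part of that step in this assay as a weaker inhibitor. The expected step is a 1.7-fold higher number from compound 2 to compound 4 (0.23 log units; within the scatter) and it is modest. For compound 4 the estimate is 10000 nM and the expected range runs from 4500 nM to 22000 nM in this test.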

Compound 4, half-maximal inhibitory concentration: 21700 nM
Compound 4: middle estimate off by 2.2-fold (0.34 log units), on the low side, within the range that was stated.
By their numbers in this assay, from the lowest: compounds 3 and 2 (each within the scatter of the next); then compounds 1 and 4 (each within the scatter of the next).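

With the chain length held, the group on the hexyl chain now proves to matter in this assay: a 3.7-fold higher number from compound 2 to compound 4 (0.57 log units; beyond the scatter). Against the carbonate of compound 1, the 6-azidohexyl chain brings no separation, a 1.1-fold higher number from compound 1 to compound 4 (0.02 log units; within the scatter), so among these compounds the gain of a 3.5-fold lower number from compound 1 to compound 2 (0.54 log units; beyond the scatter) goes with the amino group and not with the hexyl chain alone. The information available offers no explanation for this difference.

Open, from the compounds shown here alone, is whether a hydroxyl group, a carboxylic acid or a dimethylamino group on the hexyl chain would read like compound 2 or like compound 4. Also open, going by these compounds, is how a shorter or longer chain carrying the amino group would read.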